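From Compound 1 to Compound 4: Swapping the Benzyl Arm

The source may hold more compounds than are shown below. What is called first, only, known or untested is meant among the compounds shown, and "the series" means these compounds.

Measured compounds in an assay on isolated protein for inhibition of Nicotinamide phosphoribosyltransferase (Homo sapiens), read by fluorescence, with stated times of 5 min and 15 min; a lower number here means a stronger inhibitor, a higher number a weaker inhibitor:
- Compound 1 `Cc1ccc(CNC(=S)Nc2ccc(C(=O)Nc3ccccc3N)cc2)cn1` gives > 2000 nM, a limit of the assay.
- Compound 2 `Nc1ccccc1NC(=O)c1ccc(CNC(=O)c2cc3cccnc3[nH]2)cc1` gives > 2000 nM, also a limit.
- Compound 3 `Nc1ccccc1NC(=O)c1ccc(CNC(=O)c2cc3cnccc3[nH]2)cc1` gives > 2000 nM, again a limit.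

Compound 1 therefore stands only at a limit, not at a number, and so do the other two compounds: the limit of > 2000 nM in this assay, at which 3 of the 3 values shown sit. Among the measured compounds shown here, the single step among measured pairs, a step that the two limits leave unreadable from compound 2 to compound 3, is unreadable, since both ends are limits.

Compound 4 `Nc1ccccc1NC(=O)c1ccc(NC(=S)NCc2cccc(Cl)c2)cc1` has not been measured. It differs from compound 1 by 3-chlorophenyl in place of 6-methylpyridin-3-yl on a saturated chain carbon bound to an amide-type nitrogen. No measured step touches this change; nothing shown reaches below the limit at all. The expectation for compound 4 is therefore that it too most likely sits at or near that limit, with a step that the limit leaves unreadable from compound 1 to compound 4 expected to be small. The estimate for compound 4 in this assay is 3000 nM, within a range from 800 nM to 20000 nM.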

Compound 4, half-maximal inhibitory concentration: > 2000 nM
Compound 4: no number, only a limit; the forecaster's own chance of this, stated with the estimate: 75%; the middle value does not contradict the limit.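

In this assay compound 4 gives > 2000 nM, a limit and not a number. Compound 1 also stands at a limit, so no step can be read from compound 1 to compound 4. The compounds shown leave open whether 3-chlorophenyl in place of 6-methylpyridin-3-yl changes inhibition at all, since none reaches a readable number: the limit of > 2000 nM in this assay, at which 4 of the 4 values shown sit.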